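The compounds below may be only part of what the source reports. "The series", "measured", "known", "first", "only" and "open" are said of these compounds alone.

Working notes on the series, read in an ADME assay on Karpas-1106P cells (Homo sapiens) for cytotoxicity; a higher number here means that more compound is needed for the effect, a lower number that less compound is needed. Compound 1 (`Cc1ccc(S(=O)(=O)N[C@@H](CC(=O)NC(C)(C)C)C(=O)NCCNC(=O)c2ccccc2)cc1`) gives > 11100 nM, which is a limit and not a number. Compound 2 (`Cc1ccc(S(=O)(=O)N[C@@H](CC(=O)NC(C)(C)C)C(=O)NCCNC(=O)c2ccccc2Cl)cc1`) gives > 11100 nM, which is also a limit and not a number. Compound 2 therefore has no numeric standing, and the whole picture so far is the limit of > 11100 nM in this assay, at which 2 of the 2 values shown sit.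

The next structure is compound 3 (`Cc1ccc(S(=O)(=O)N[C@@H](CC(=O)NC(C)(C)C)C(=O)NCCNC(=O)c2ccc(F)cc2)cc1`), with 4-fluorophenyl in place of 2-chlorophenyl on a carbonyl carbon. For the measured compounds named here, the only measured step that bears on this change is a step that the two limits leave unreadable from compound 1 to compound 2, with chloro in place of hydrogen on an aromatic carbon. That step offers no size to carry forward, so no shift beyond the scatter is expected in this assay, and no direction can be assigned with any confidence. The expected move is a step that the limit leaves unreadable from compound 2 to compound 3. Another limit is the most likely report for compound 3. If a number is obtained, the estimate for compound 3 is 14000 nM, with an expected range from 7000 nM to 30000 nM.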

Compound 3, half-maximal effective concentration: > 11100 nM
Compound 3 ended at the assay's limit; the forecaster's own chance of this, stated with the estimate: 85%; the middle value lies beyond the limit too.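

Compound 3 also gives a limit and not a number in this assay, so no step among compound 1, compound 2 and compound 3 can be read: the limit of > 11100 nM in this assay, at which 3 of the 3 values shown sit.

The compounds shown leave open whether the chloro or fluoro changes have any effect, and whether any member of this series gives a numeric half-maximal effective concentration in this assay.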